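A few compounds are considered here, and "the series" means these few. Any claim that something is new, unique, unknown or untested is made for them only; others in the source may bear on it.

Working notes on the series. Compound 1 `Cc1cc(C)n2nccc2n1` gives 60 mg/kg in a functional assay on the whole organism with Rattus norvegicus as the target; on this read-out higher numbers stand for an effect only at larger amounts of compound and lower numbers for an effect already at smaller amounts. Compound 2 `Cc1cc(C)n2ncc(F)c2n1`, which carries fluoro in place of hydrogen on an aromatic carbon, gives 80 mg/kg; the step of a 1.3-fold higher number from compound 1 to compound 2 (0.12 log units; within the scatter). Going by the values given here, of the two numbers measured so far, that of compound 2 is the larger, but it and that of compound 1 lie within the scatter of one another, so no order between them can be claimed.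

Compound 3 `Cc1cc(C)n2ncc(Cl)c2n1` is the next analogue. Its change from compound 2: chloro in place of fluoro on an aromatic carbon. Among the compounds with values here, the only measured step that bears on this position is the one from compound 1 to compound 2, and it stayed within the scatter. Within the data shown here, no step that exchanges one halogen for another has been measured, so nothing beyond the hydrogen-to-fluoro step supports any direction. The expectation is therefore a step of no change at the digits printed from compound 2 to compound 3 (within the scatter), that is, none beyond the scatter. For compound 3 the estimate in this assay is 80 mg/kg, with a range from 40 mg/kg to 160 mg/kg.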

Compound 3, minimum effective dose: 10 mg/kg
Estimate against measurement, compound 3: 8.0-fold (0.90 log units) above; measured number below the stated range.
By their numbers in this assay, from the lowest: compound 3; then compounds 1 and 2 (each within the scatter of the next).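

In this assay this aromatic carbon of the five-membered ring proves sensitive to the group it carries: chloro in place of fluoro gives an 8.0-fold lower number from compound 2 to compound 3 (0.90 log units; beyond the scatter) and chloro in place of hydrogen gives a 6.0-fold lower number from compound 1 to compound 3 (0.78 log units; beyond the scatter) so compound 3 acts at smaller amounts than either other compound. The earlier step from hydrogen to fluoro stayed within the scatter, so the position looked indifferent until chloro entered, and among the three groups shown only chloro moves the number beyond the scatter. Nothing at hand accounts for this difference between chloro and the other two groups.

From the compounds shown here alone, whether bromo, a methyl group, a nitrile or an amine on this carbon would match or pass chloro remains open. Also open, going by these compounds, is whether the chloro step would hold if the two methyl groups of the shared core were replaced by longer chains.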